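Methoxy in place of hydrogen on compound 2

A few compounds are considered here, and "the series" means these few. Any claim that something is new, unique, unknown or untested is made for them only; others in the source may bear on it.

In a functional assay on PC-3 cells (Homo sapiens) for antiproliferative activity, read by MTT assay, with a stated time of 48 h (on this read-out higher numbers stand for weaker inhibition and lower numbers for stronger inhibition), compound 1 (`COc1cc(-c2nnc(-c3cn4ccccc4n3)o2)cc(OC)c1OC`) gives 3500 nM and compound 2 (`COc1ccc(-c2nnc(-c3cn4cccc(C)c4n3)o2)cc1OC`) gives 11500 nM as the higher of the two numbers, a gap beyond the scatter. These two differ in more than one place, so the gap isolates no single change. Compound 3 (`COc1cc(-c2nnc(-c3cn4cccc(C)c4n3)o2)cc(OC)c1OC`) follows from compound 2 with methoxy in place of hydrogen on an aromatic carbon. Compound 3 shares its methoxy pattern with compound 1 at 3500 nM as the nearest reference. A step to a lower number, beyond the scatter, is expected in this assay (estimated as a 3.3-fold lower number from compound 2 to compound 3 (0.52 log units; beyond the scatter)). For compound 3 the estimate is 3500 nM with an expected range from 1200 nM to 10000 nM in this series.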

Compound 3, half-maximal inhibitory concentration: 10900 nM
Beside the measured number, compound 3's estimate is 3.1-fold (0.49 log units) below it; the measured number lies above the stated range.
By their numbers in this assay, from the lowest: compound 1; then compounds 3 and 2 (each within the scatter of the next).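

In this assay methoxy in place of hydrogen on an aromatic carbon gives a 1.1-fold lower number from compound 2 to compound 3 (0.02 log units; within the scatter) and so shows no effect beyond the scatter at this position while the methyl is present. With the methoxy pattern held fixed, adding the methyl gives a 3.1-fold higher number from compound 1 to compound 3 (0.49 log units; beyond the scatter) and is the only one of these two single changes beyond the scatter. No measurement to hand explains either step. Open, from the compounds shown here alone, is whether the methoxy step holds without the methyl, and whether an amine at the methoxy position or an ethyl at the methyl position would move the number.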